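The source may hold more compounds than are shown below. What is called first, only, known or untested is meant among the compounds shown, and "the series" means these compounds.

Measured compounds in a functional assay on V79 cells (Cricetulus griseus) for cytotoxicity, read by colony formation; a lower number here means a stronger inhibitor, a higher number a weaker inhibitor:

Compound 1 `COc1c(N2CCCC2)c(F)cc2c(=O)c(C(=O)O)cn(C3CC3)c12` gives 150 ug/mL. Compound 2 `O=C(O)c1cn(C2CC2)c2c(C(F)(F)F)c(N3CCCC3)c(F)cc2c1=O` gives 280 ug/mL. Compound 3 `CNCC1(C)CCN(c2c(F)cc3c(=O)c(C(=O)O)cn(C4CC4)c3c2OC)C1` gives 120 ug/mL.

Compound 2 differs from compound 1 by trifluoromethyl in place of methoxy on an aromatic carbon; the step was a 1.9-fold higher number from compound 1 to compound 2 (0.27 log units; within the scatter). Compound 3 differs from compound 1 by 3-methyl-3-((methylamino)methyl)pyrrolidin-1-yl in place of pyrrolidin-1-yl on an aromatic carbon; the step was a 1.3-fold lower number from compound 1 to compound 3 (0.10 log units; within the scatter).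

Compound 4 `CNCC1(C)CCN(c2c(F)cc3c(=O)c(C(=O)O)cn(C4CC4)c3c2C(F)(F)F)C1` is not yet measured. It differs from compound 3 by trifluoromethyl in place of methoxy on an aromatic carbon. This is the same kind of change as that from compound 1 to compound 2, not the same: there the place was ortho to a pyrrolidin-1-yl group, here it is ortho to a 3-methyl-3-((methylamino)methyl)pyrrolidin-1-yl group. Among the compounds with values here, only one measured example of this kind of change exists, so the expectation rests on it alone. For compound 4 the expected step in this assay is a 1.8-fold higher number from compound 3 to compound 4 (0.26 log units; within the scatter), of about the size seen because of a 1.9-fold higher number from compound 1 to compound 2 (0.27 log units; within the scatter). Compound 4 is therefore estimated at 220 ug/mL, expected to lie between 110 ug/mL and 440 ug/mL.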

Compound 4, half-maximal inhibitory concentration: 230 ug/mL
The estimate for compound 4 lay 1.0-fold (0.02 log units) below the measured number, within the range that was stated.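

In this assay, trifluoromethyl in place of methoxy gives a 1.9-fold higher number from compound 3 to compound 4 (0.28 log units; within the scatter), and this step agrees with the one on the core of compound 1: the same change on two cores in this assay, a 1.9-fold higher number (0.27 log units; within the scatter) from compound 1 to compound 2 and a 1.9-fold higher number (0.28 log units; within the scatter) from compound 3 to compound 4, 1.0-fold (0.01 log units) apart, within the scatter of two such steps. Likewise, 3-methyl-3-((methylamino)methyl)pyrrolidin-1-yl in place of pyrrolidin-1-yl gives a 1.2-fold lower number from compound 2 to compound 4 (0.09 log units; within the scatter), which agrees with its counterpart: the same change on two cores in this assay, a 1.3-fold lower number (0.10 log units; within the scatter) from compound 1 to compound 3 and a 1.2-fold lower number (0.09 log units; within the scatter) from compound 2 to compound 4, 1.0-fold (0.01 log units) apart, within the scatter of two such steps. Within the data shown here, all four steps lie within the scatter, so the agreement shows only that neither change shifts this read-out beyond the scatter on these two cores; it does not show that a larger effect would carry over, or that the same holds on other cores.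

Still open, from the compounds shown here alone, is whether a nitrile or a chlorine in place of methoxy would behave the same way. An amide in place of the carboxylic acid is also untested by these compounds.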